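A few compounds are considered here, and "the series" means these few. Any claim that something is new, unique, unknown or untested is made for them only; others in the source may bear on it.

Measured compounds:
compound 1 `O=C(Nc1ccc(Cl)cc1)C(Cl)Cl` gives 49600 nM
compound 2 `O=C(Nc1ccc(I)cc1)C(Cl)Cl` gives 11900 nM

Both numbers come from a functional assay on Bel-7402 cells (Homo sapiens) for antiproliferative activity, read by MTT assay, with a stated time of 72 h; a higher number here means a weaker inhibitor, a lower number a stronger inhibitor. Compound 2 stands at the lower of the two numbers; its nearest neighbour is compound 1, and the step of a 4.2-fold lower number from compound 1 to compound 2 (0.62 log units; beyond the scatter) lies beyond the scatter.

Compound 3 `COc1ccc(NC(=O)C(Cl)Cl)cc1` is not yet measured. It differs from compound 2 by methoxy in place of iodo on an aromatic carbon, on an aromatic carbon of the six-membered aromatic ring of carbon only, para to a group of 6 heavy atoms.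

Going by the values given here, the one measured step, a 4.2-fold lower number from compound 1 to compound 2 (0.62 log units; beyond the scatter), exchanges one halogen for another at the same carbon and so bears only loosely on a methoxy entering there. Among the compounds with values here, no measured compound carries a methoxy or any oxygen-bearing group on the ring, so the direction rests on little. Within the data shown here, since the lowest number so far belongs to compound 2 with 11900 nM, compound 3 is expected to move back toward compound 1, a step of a 2.9-fold higher number from compound 2 to compound 3 (0.47 log units; beyond the scatter) in this assay. The estimate for compound 3 is 35000 nM, with a range from 11000 nM to 110000 nM.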

Compound 3, half-maximal inhibitory concentration: 192000 nM
Beside the measured number, compound 3's estimate is 5.5-fold (0.74 log units) below it; the measured number lies above the stated range.
By their numbers in this assay, from the lowest: compound 2; then compound 1; then compound 3.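

In this assay, this position turns out to tolerate change in both directions: the halogen pair alone showed only a fall in the number, whereas methoxy raises it past both halogens, with a 16-fold higher number from compound 2 to compound 3 (1.21 log units; beyond the scatter) against iodo and a 3.9-fold higher number from compound 1 to compound 3 (0.59 log units; beyond the scatter) against chloro. With both steps beyond the scatter, the order at this carbon, from lowest number to highest, runs iodo, chloro, methoxy, and compound 3 is the weakest of the three. Nothing available accounts for the rise on moving from either halogen to methoxy.

Open, as far as these compounds go, is whether the rise follows the oxygen of the methoxy or simply the loss of a halogen; a methyl, an amine or a bromo at the same carbon would help separate these. Also open, from the compounds shown here alone, is whether this order holds when another part of the shared core changes.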